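The compounds below may be only part of what the source reports. "The series", "measured", "known", "first", "only" and "open" are said of these compounds alone.

Values in an ADME assay on the whole organism (strain Sprague-Dawley) for metabolic stability, with Rattus norvegicus as the target, read by LC-MS (a higher number here means that the compound lasts longer, a lower number that the compound disappears faster), so far:
compound 1 `CC(Oc1nn(-c2ccccc2F)c2ccc(F)cc12)C(=O)N1CCOCC1` gives 2 h
compound 2 `O=C1NCCN1CCOc1nn(-c2ccccc2F)c2ccc(F)cc12` gives 0.4 h
compound 3 `O=C1NCCN1CCOc1nn(-c2ccc(F)cc2F)c2ccc(F)cc12` gives 0.94 h

Compound 3 holds the middle place, second highest of the three numbers, with compound 1 higher and compound 2 lower, both gaps beyond the scatter. The next change leads to compound 4 `O=C1NCCN1CCOc1nn(-c2ccc(F)cc2)c2ccc(F)cc12` and reads hydrogen in place of fluoro on an aromatic carbon (hydrogen in place of fluoro on an aromatic carbon, 2,4-difluorophenyl to 4-fluorophenyl). Among the measured compounds shown here, one measured step bears on it: a 2.4-fold higher number from compound 2 to compound 3 (0.37 log units; beyond the scatter) for fluoro in place of hydrogen on an aromatic carbon, a modest step. For the measured compounds named here, the fluoro leaving now is not the one that step brought in, and compound 4 keeps that one. Going by the values given here, no measured step covers the fluoro that leaves, so only a weak guide exists. In this assay the expected step is a 1.2-fold lower number from compound 3 to compound 4 (0.07 log units; within the scatter) and so none clearly beyond the scatter. Compound 4 is estimated at 0.8 h with a range from 0.4 h to 1.6 h for the coming measurement.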

Compound 4, half-life: 0.7 h
Compound 4: the middle estimate sits 1.1-fold (0.06 log units) above what was measured, within the range that was stated.
By their numbers in this assay, from the lowest: compounds 2, 4 and 3 (each within the scatter of the next, the first and the last beyond it); then compound 1.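

In this assay, hydrogen in place of the fluoro ortho to a large group gives a step within the scatter (a 1.3-fold lower number from compound 3 to compound 4 (0.13 log units; within the scatter)), so at this place on the 2,4-difluorophenyl group the two cannot be told apart. Moving the single fluoro also stays within the scatter, as 4-fluorophenyl in place of 2-fluorophenyl on the aromatic nitrogen shows (a 1.8-fold higher number from compound 2 to compound 4 (0.24 log units; within the scatter)). Among these three compounds, only the step to the 2,4-difluorophenyl group lies beyond the scatter (a 2.4-fold higher number from compound 2 to compound 3 (0.37 log units; beyond the scatter)), so neither single fluoro position stands apart from the other.

The compounds shown leave open whether a chloro or methoxy group at this place would give a step beyond the scatter. They also leave open how these aryl groups read with the side chain of compound 1. No measured evidence bears on the reason for these steps.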